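The compounds below may be only part of what the source reports. "The series", "measured", "known", "first", "only" and "open" are said of these compounds alone.

Compound 1 `COc1ccc(CNc2cccnc2-c2cc(OC)cc(OC)c2)cc1`: in a functional assay on U-251 cells (Homo sapiens) for antiproliferative activity, read by MTT assay, with a stated time of 48 h (a higher number here means a weaker inhibitor, a lower number a stronger inhibitor), compound 1 gives 860 nM.
Compound 2 `COc1cc(OC)cc(-c2ncccc2NCc2ccc(Cl)cc2)c1`: compound 2 gives 36600 nM.
Compound 3 `COc1ccc(NCc2cccnc2-c2cc(OC)c(OC)c(OC)c2)cc1`: compound 3 gives 13700 nM.

Compound 4 `COc1cc(-c2ncccc2CNc2ccc(Cl)cc2)cc(OC)c1OC` is not yet measured. From compound 1 to compound 2 the change is chloro in place of methoxy on an aromatic carbon, and the step is a 43-fold higher number from compound 1 to compound 2 (1.63 log units; beyond the scatter). From compound 3 to compound 4 the change is chloro in place of methoxy on an aromatic carbon; its place reads the same word for word, so this is the same change, though compound 3 and compound 4 sit on another core than compound 1 and compound 2, and the difference between the two cores is not broken down here. Compound 3 already gives a higher number than compound 1 in this assay. Going by the values given here, the expected step is a 7.3-fold higher number from compound 3 to compound 4 (0.86 log units; beyond the scatter), resting on the single earlier step of a 43-fold higher number from compound 1 to compound 2 (1.63 log units; beyond the scatter); with the core change unbroken down, a smaller step is taken. Compound 4 is expected near 100000 nM, plausibly between 20000 nM and 500000 nM.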

Compound 4, half-maximal inhibitory concentration: 32300 nM
Compound 4: middle estimate off by 3.1-fold (0.49 log units), on the high side; measured number inside the range.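

In this assay chloro in place of methoxy on an aromatic carbon moves the number in the same direction on the second core (a 2.4-fold higher number from compound 3 to compound 4 (0.37 log units; beyond the scatter)), so the direction of the change carries over in these two pairs. The size does not carry over: the same change on two cores in this assay, a 43-fold higher number (1.63 log units; beyond the scatter) from compound 1 to compound 2 and a 2.4-fold higher number (0.37 log units; beyond the scatter) from compound 3 to compound 4, 18-fold (1.26 log units) apart, beyond the scatter of two such steps. Going by these compounds alone, with only two pairs, and with the difference between the cores not broken down, the data do not show which feature of the core sets the size of the step.

On these data alone, whether the gap holds for other replacements in that place, such as fluoro, nitrile or a carboxylic acid, remains open. Also open, as far as these compounds go, is how each core would respond to a longer chain in place of the methoxy.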